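This account rests on a few compounds, and the source may have more. Where it says the series, first, only, none or still open, it means among the compounds named here.

Measured so far, and still open:

Compound 1 `CCNC(=O)c1noc(-c2cc(C(C)C)c(O)cc2O)c1-c1cc(CN(CC)CC)no1`: 78 nM
Compound 2 `CCNC(=O)c1noc(-c2cc(C(C)C)c(O)cc2O)c1-c1cc(C(N)=O)no1`: 15 nM
Compound 3 `CCNC(=O)c1cc(-c2c(C(=O)NCC)noc2-c2cc(C(C)C)c(O)cc2O)on1`: not yet measured

Going by the values given here, in a functional assay on A2780 cells (Homo sapiens) for inhibition (on this read-out lower numbers stand for stronger inhibition and higher numbers for weaker inhibition), compound 2 gives 15 nM, the lower of the two numbers so far, while compound 1 stands at 78 nM. Compound 3 departs from compound 2 in one place: ethyl in place of hydrogen on an amide-type nitrogen. In words, ethyl takes the place of hydrogen on an amide-type nitrogen, so carbamoyl becomes ethylcarbamoyl.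

Among the compounds with values here, only one measured step bears on this, namely a 5.2-fold lower number from compound 1 to compound 2 (0.72 log units; beyond the scatter). There, carbamoyl replaced (diethylamino)methyl on an aromatic carbon. That step is modest but beyond the scatter, and it involves the same carbamoyl group that now gains the ethyl. Within the data shown here, it does not measure the ethyl change itself, and no measured pair does. A smaller step than that one is therefore expected in this assay, leaning slightly towards a higher number and possibly staying within the scatter.

The expected change is a 1.5-fold higher number from compound 2 to compound 3 (0.17 log units; within the scatter). Compound 3 is estimated at 22 nM, with an expected range of 8 nM to 60 nM.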

Compound 3, half-maximal inhibitory concentration: 43 nM
Compound 3: the middle estimate sits 2.0-fold (0.29 log units) below what was measured, and the stated range covers the measured number.
By their numbers in this assay, from the lowest: compound 2; then compounds 3 and 1 (each within the scatter of the next).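

Ethyl on the amide-type nitrogen gives a 2.9-fold higher number from compound 2 to compound 3 (0.46 log units; beyond the scatter) in this assay and thereby shows for the first time that this nitrogen is not indifferent to substitution: replacing the amide hydrogen with ethyl gives up part of the advantage that carbamoyl showed over (diethylamino)methyl. Going by these compounds alone, measured directly against the (diethylamino)methyl compound, ethylcarbamoyl gives a 1.8-fold lower number from compound 1 to compound 3 (0.26 log units; within the scatter) and so holds no advantage over that group that stands clear of the usual scatter, which makes the unsubstituted carbamoyl of compound 2 the only group here that stands apart from (diethylamino)methyl on this read-out. No measurement offered here accounts for the size of this shift, so the step can only be recorded as it stands.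

A single ethyl cannot tell whether the number would rise further with a propyl or a longer chain on the same nitrogen, or whether a methyl alone would already produce a similar step. As far as these compounds go, it also remains open whether a carboxylic acid or a nitrile in place of the carbamoyl group would come close to compound 2 at 15 nM in this assay.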